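The source may report more compounds than this note shows. Statements on the series, on what has been measured and on what is new or still open speak of the compounds shown alone.

Measured so far in a functional assay on A498 cells (Homo sapiens) for inhibition, read by sulforhodamine B assay, with a stated time of 48 h; a higher number here means a weaker inhibitor of growth, a lower number a stronger inhibitor of growth:

Compound 1, `Nc1cc(N)c2nc(-c3ccccc3)c(Oc3ccc(Cl)c(Cl)c3)nc2c1`: 91200 nM
Compound 2, `CCOC(=O)[C@H](CCC(=O)O)NC(=O)c1ccc(Sc2nc3cc(N)cc(N)c3nc2-c2ccccc2)cc1`: 49000 nM
Compound 3, `CCOC(=O)[C@H](CCC(=O)O)NC(=O)c1ccc(Oc2nc3cc(N)cc(N)c3nc2-c2ccccc2)cc1`: 6310 nM

Among these three, compound 1 stands at the highest number in this assay. Its nearest neighbour is compound 2, whose number lies within the usual scatter of compound 1, so the two cannot be told apart. Compound 3 gives a clearly lower number, a gap beyond the scatter, so compound 3 is the stronger growth inhibitor of that pair.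

Compound 4, `Nc1cc(N)c2nc(-c3ccccc3)c(NCc3ccc(F)cc3)nc2c1`, has not yet been measured. It differs from compound 1 in one place: (4-fluorobenzyl)amino in place of 3,4-dichlorophenoxy on an aromatic carbon. Among the compounds with values here, no measured pair shows exactly this kind of exchange, so no step can be read off directly; the only guide is that compound 3 shows how far a change at the same part of the core can move the number. A modest shift toward a lower number is expected in this assay, though a result within the scatter would not surprise. The estimated step from compound 1 to compound 4 is a 2.3-fold lower number from compound 1 to compound 4 (0.36 log units; beyond the scatter). Compound 4 is expected to give about 40000 nM, with a likely range from 8000 nM to 200000 nM.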

Compound 4, concentration for 50% growth inhibition: 17000 nM
For compound 4 the middle estimate is 2.4-fold (0.37 log units) above the measured one, and the stated range covers the measured number.
By their numbers in this assay, from the lowest: compound 3; then compound 4; then compounds 2 and 1 (each within the scatter of the next).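

In this assay, within the data shown here, placing (4-fluorobenzyl)amino instead of 3,4-dichlorophenoxy on the aromatic carbon next to the ring nitrogen gives a 5.4-fold lower number from compound 1 to compound 4 (0.73 log units; beyond the scatter) with the rest of the molecule unchanged, the first one-place comparison here, and it shows that the number responds to the group at this position. The two groups have the same heavy-atom count and each has one six-membered aromatic ring of carbon only, but they differ in their link to the core, their halogens and their hydrogen-bond donors, so this one step cannot be assigned to any single difference. No supporting data explain the shift.

As far as these compounds go, it remains open whether the nitrogen link or the halogen swap carries the step. Plain benzylamino and 3,4-dichlorobenzylamino groups at this position would help to separate the two.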